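Notes on compounds 1 to 4: shortening the ketone chain

The compounds below may be only part of what the source reports. "The series", "measured", "known", "first", "only" and "open" are said of these compounds alone.

Compound 1 `CCCC(=O)c1ccc(OCCCCOc2cccc(C(=O)O)c2C)c(C)c1O` gives 82.4% in an assay on HEK293 cells for positive allosteric modulation of metabotropic glutamate receptor 2 (Rattus norvegicus), read by thallium flux, with a stated time of 2.5 min; a higher number here means a larger maximal response, a lower number a smaller maximal response.
Compound 2 `Cc1c(OCCCCOc2ccc(C(=O)C(C)C)c(O)c2C)cccc1C(=O)O` gives 66.9% in this assay.
Compound 3 `Cc1c(OCCCCOc2ccc(C(=O)CC(C)(C)C)c(O)c2C)cccc1C(=O)O` gives 95.8% in this assay.

Compound 3 stands highest of the three in this assay. Its nearest neighbour is compound 1, see a number 13.4 percentage points higher from compound 1 to compound 3 (beyond the scatter); furthest is compound 2, see a number 28.9 percentage points higher from compound 2 to compound 3 (beyond the scatter). Compound 4 `CC(=O)c1ccc(OCCCCOc2cccc(C(=O)O)c2C)c(C)c1O` is not yet measured. It differs from compound 3 in one place: hydrogen in place of tert-butyl on a saturated chain carbon bound to a carbonyl carbon.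

All three measured steps concern the same chain on the carbonyl and so bear on this change: a number 15.5 percentage points lower from compound 1 to compound 2 (beyond the scatter), a number 13.4 percentage points higher from compound 1 to compound 3 (beyond the scatter) and a number 28.9 percentage points higher from compound 2 to compound 3 (beyond the scatter). They are all modest and do not run in one direction with chain shape, compound 2 going against any simple ordering. The change to compound 4 removes the whole group that separated compound 3 from compound 1 and goes further still, so a decrease beyond the scatter is expected, of the size a number 30.8 percentage points lower from compound 3 to compound 4 (beyond the scatter). The value of compound 4 is estimated at 65%, with a range from 40% to 90%.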

Compound 4, largest response reached (reported as percent of maximum), in percent of the reference or control that the assay uses: 79.2%
Compound 4: the middle estimate sits 14.2 percentage points below what was measured; the measured number falls inside the stated range.
By their numbers in this assay, from the lowest: compound 2; then compounds 4 and 1 (each within the scatter of the next); then compound 3.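

Taking out the tert-butyl lowers the response (a number 16.6 percentage points lower from compound 3 to compound 4 (beyond the scatter)), but the acetyl compound still stands above the isopropyl ketone (a number 12.3 percentage points higher from compound 2 to compound 4 (beyond the scatter)). Hydrogen in place of ethyl on the saturated chain carbon bound to the carbonyl carbon stays within the scatter (a number 3.2 percentage points lower from compound 1 to compound 4 (within the scatter)), so in this assay this shortening of the ketone chain gives no readable difference, and chain length alone does not order the series: compound 3 and compound 2 both depart from compound 4 and compound 1, in opposite directions. No measurement shown here accounts for these steps.

Going by these compounds, it remains open whether a chain longer than neopentyl would raise the response further or lower it. Also open, on these data alone, is how an amine or a carboxylic acid on the ketone chain would read in this assay.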